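Working notes: chloro to cyclopropyl on the amide chain

The compounds below may be only part of what the source reports. "The series", "measured", "known", "first", "only" and "open" are said of these compounds alone.

Measured so far:
compound 1 `CO[C@]1(C(=O)O)C[C@H](O)[C@@H](NC(C)=O)[C@H]([C@@H](O)[C@H](O)CNC(=O)c2ccccc2)O1` — 137000 nM
compound 2 `O=C(CCl)N[C@H]1[C@H]([C@@H](O)[C@H](O)CNC(=O)c2ccc(Cl)cc2)O[C@@](OCc2cccc(F)c2F)(C(=O)O)C[C@@H]1O` — 2100 nM

In an in vitro assay on cells for binding affinity to myelin-associated glycoprotein (Mus musculus), read by surface plasmon resonance (on this read-out higher numbers stand for weaker binding and lower numbers for tighter binding), compound 2 gives 2100 nM, the lowest of the two numbers; compound 1 gives 137000 nM, a higher number that lies beyond the scatter. Compound 3 `O=C(CC1CC1)N[C@H]1[C@H]([C@@H](O)[C@H](O)CNC(=O)c2ccc(Cl)cc2)O[C@@](OCc2cccc(F)c2F)(C(=O)O)C[C@@H]1O` differs from compound 2 in one place: cyclopropyl in place of chloro on a saturated chain carbon bound to a carbonyl carbon. Within the data shown here, no step between measured compounds covers this change, so there is no anchor for its size. A modest step toward a higher number is expected, estimated as a 2.1-fold higher number from compound 2 to compound 3 (0.33 log units; beyond the scatter). For compound 3 the expected value is 4500 nM, with a range from 1200 nM to 18000 nM.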

Compound 3, dissociation constant in the myelin-associated glycoprotein assay: 4100 nM
The estimate for compound 3 lay 1.1-fold (0.04 log units) above the measured number; measured number inside the range.
By their numbers in the myelin-associated glycoprotein assay, from the lowest: compounds 2 and 3 (each within the scatter of the next); then compound 1.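

In the myelin-associated glycoprotein assay the place on a saturated chain carbon bound to a carbonyl carbon accepts cyclopropyl in place of chloro: compound 2 gives 2100 nM and compound 3 gives 4100 nM, with a 2.0-fold higher number from compound 2 to compound 3 (0.29 log units; within the scatter), so chlorine is not required there for binding on this core. In a physicochemical assay for lipophilicity, using the shake flask method, measured as octanol-water partition, at pH 7.4 (a higher number here means a more lipophilic compound, a lower number a more polar compound), compound 2 gives 0.35 and compound 3 gives 0.31, with a number 0.04 log units lower from compound 2 to compound 3 (within the scatter), so neither read-out separates the two compounds. Nothing at hand offers a measured explanation for this.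

Open, as far as these compounds go, is how an amine, a hydroxyl or a longer chain would read at this place. From the compounds shown here alone, this change also stands on the core of compound 2 alone, so its reading on other cores remains unknown.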